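A few compounds are considered here, and "the series" means these few. Any claim that something is new, unique, unknown or untested is made for them only; others in the source may bear on it.

Measured so far:
- compound 1, `Cc1nc(-c2ccccc2)c(C(=O)N2CCN(c3ccccc3Cl)CC2)o1`: 124 nM
- compound 2, `COc1cc(OC)cc(N2CCN(C(=O)c3onc(C)c3-c3cccc(F)c3)CC2)c1`: 152 nM

Both were run in a functional assay on HL-60 cells (Homo sapiens) for inhibition, read by MTT assay, with a stated time of 72 h; on this read-out higher numbers stand for weaker inhibition and lower numbers for stronger inhibition. Compound 1 holds the lowest of the two numbers in this assay, giving 124 nM, but the nearest point, compound 2 with 152 nM, lies within the scatter of it, so no order can be read between the two. Compound 2 also differs from compound 1 in more than one place, so nothing can be said about any single change from these two values.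

The next compound, compound 3, `Cc1nc(-c2ccccc2)c(C(=O)N2CCN(c3ccccc3C(F)(F)F)CC2)o1`, is still to be measured in this assay. It differs from compound 1 in one place: trifluoromethyl in place of chloro on an aromatic carbon. Among the measured compounds shown here, no measured pair shows this change, so there is no step on which to lean. With only the value of compound 1 as anchor, the step from compound 1 to compound 3 is expected to be small, with no direction established beyond the scatter: a 1.4-fold higher number from compound 1 to compound 3 (0.14 log units; within the scatter). Compound 3 is therefore estimated at 170 nM, in a range from 70 nM to 400 nM.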

Compound 3, half-maximal inhibitory concentration: 120 nM
The estimate for compound 3 lay 1.4-fold (0.15 log units) above the measured number; the range from low to high includes it.
By their numbers in this assay, from the lowest: compounds 3, 1 and 2 (each within the scatter of the next).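

In this assay, among the compounds shown here, trifluoromethyl in place of chloro on an aromatic carbon, ortho to a large group, gives a 1.0-fold lower number from compound 1 to compound 3 (0.01 log units; within the scatter) and is the only single-place step so far. At this position, 2-chlorophenyl and 2-(trifluoromethyl)phenyl cannot be told apart by this read-out, even though the entering group has 4 heavy atoms and the leaving group 1. No measurement shown bears on why the two groups read alike.

The compounds shown leave open whether this position accepts groups of another kind, such as an amine, a carboxylic acid or a longer alkyl chain, as readily as it accepts these two. As far as these compounds go, it also remains open whether trifluoromethyl in place of chloro would read the same way on a compound other than compound 1.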